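Swapping Phenyl for Methyl on Two Related Cores

The source may report more compounds than this note shows. Statements on the series, on what has been measured and on what is new or still open speak of the compounds shown alone.

Of the compounds shown here, three have so far been measured in an assay on isolated protein for inhibition of ribosomal protein S6 kinase alpha-5 (Homo sapiens), read by mobility shift assay, tested at 30 uM; on this read-out lower numbers stand for less inhibition and higher numbers for more inhibition at the one concentration tested (going by the name of the read-out). Compound 1 `Cc1cc2c(c(N)nn2C)c(=O)[nH]1` gives 4%, compound 2 `Cn1nc(N)c2c(=O)[nH]c(-c3ccccc3)cc21` gives 9%, and compound 3 `Cc1cc2nc(-c3ccccc3)nc(N)c2c(=O)[nH]1` gives 15%. Compound 3 holds the highest of the three numbers; its gap to compound 2 lies within the scatter, while its gap to compound 1 lies beyond it. The change from compound 2 to compound 1 is methyl in place of phenyl on an aromatic carbon, and this step gave a number 5 percentage points lower from compound 2 to compound 1 (within the scatter). The difference between the core of compound 3 and the core of compound 2 is not broken down here.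

Compound 4 `Cc1nc(N)c2c(=O)[nH]c(C)cc2n1` has not yet been measured in this assay. It arises from compound 3 by methyl in place of phenyl on an aromatic carbon, the same kind of change as that from compound 2 to compound 1, though the surroundings differ: in compound 2 the phenyl sits on a six-membered aromatic ring with 1 nitrogen, next to the ring nitrogen and meta to a group of 1 heavy atom, whereas in compound 3 it sits on a six-membered aromatic ring with 2 nitrogen, between two ring nitrogen atoms and meta to an amino group (1 heavy atom). Because the earlier step was a number 5 percentage points lower from compound 2 to compound 1 (within the scatter), a similar small step is expected here, namely a number 5 percentage points lower from compound 3 to compound 4 (within the scatter). Among the measured compounds shown here, only a single measured pair supports this, so the expectation is loose. Compound 4 is therefore estimated at 10% in this assay, with a likely range from 2% to 20%.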

Compound 4, a percentage reported as inhibition, at one concentration (the size of the read-out at that concentration, not a potency): 0%
The estimate for compound 4 lay 10 percentage points above the measured number, outside the stated range (below it).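

On the core of compound 3, putting methyl in place of phenyl on an aromatic carbon gave a number 15 percentage points lower from compound 3 to compound 4 (beyond the scatter) in this assay. Set beside the earlier case, the size of this step cannot be told apart from the size of the first: the same change on two cores in this assay, a number 5 percentage points lower (within the scatter) from compound 2 to compound 1 and a number 15 percentage points lower (beyond the scatter) from compound 3 to compound 4, 10 percentage points apart, within the scatter of two such steps So the two cores give no sign that the change behaves differently from one to the other, but this does not prove that it behaves the same, as the comparison rests on only two pairs, read at a single concentration, and the first step on its own cannot be told from the scatter.

All four compounds shown carry either phenyl or methyl at this place, so it remains open how the numbers would read with an amine, a carboxylic acid or a longer chain such as butyl there. Equally open, as far as these compounds go, is what would happen with a hydroxyl group or a longer amine in place of the amino group that all four compounds carry.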